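The compounds below may be only part of what the source reports. "The series", "measured", "known", "first", "only" and "open" are said of these compounds alone.

The series shares one core, shown for compound 1 as `O=c1c(C(=S)Nc2ccccc2)coc2ccccc12`, where the side chain is open. In a functional assay on COLO 205 cells (Homo sapiens) for inhibition, read by sulforhodamine B assay, with a stated time of 48 h (on this read-out lower numbers stand for stronger inhibition and higher numbers for weaker inhibition), compound 1 gives 72600 nM. Compound 2, `O=c1c(C2N=C(c3ccccc3)SS2)coc2ccccc12`, closes that side chain into a ring. In this assay compound 2 reaches only the limit of > 100000 nM, so no number is known for it. Compound 3, `O=c1c(C2N=C(c3ccccc3)SS2)coc2cc(Cl)ccc12`, carries a chloro on the core. In this assay compound 3 gives 76700 nM. Among the compounds with values here, the one measured step, an at least 1.3-fold lower number from compound 2 to compound 3 (0.11 log units; that floor lies within the scatter), is bounded by the limit of > 100000 nM in this assay, at which 1 of the 3 values shown sits, and so is known only as a floor that does not rise beyond the scatter.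

Compound 4, `Cc1ccc2occ(C3N=C(c4ccccc4)SS3)c(=O)c2c1`, changes compound 2 in the following way: methyl in place of hydrogen on an aromatic carbon. Within the data shown here, the only step that bears on this, a different small group entering on the core of compound 2, is an at least 1.3-fold lower number from compound 2 to compound 3 (0.11 log units; that floor lies within the scatter), which is read against the limit of compound 2. Since compound 1 and compound 3 both sit in the same weak region, and the chloro change gave no clear movement, the methyl change in compound 4 is expected to give no step beyond the scatter, or at most a small lowering of the number.

The estimated step is therefore an at least 1.1-fold lower number from compound 2 to compound 4 (0.04 log units; that floor lies within the scatter). For compound 4 in this assay the expected value is 90000 nM, with a range from 40000 nM to 200000 nM.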

Compound 4, half-maximal inhibitory concentration: > 100000 nM
Compound 4 ended at the assay's limit (the forecaster's own chance of this, stated with the estimate: 40%); middle value at least 1.1-fold (0.04 log units) away from the limit.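

In this assay, compound 4 gives only a limit, > 100000 nM, and not a number. Compound 2 also sits at a limit, so the step between compound 2 and compound 4 cannot be read: the limit of > 100000 nM in this assay, at which 2 of the 4 values shown sit.

The compounds shown leave open whether methyl in place of hydrogen changes the number at all.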